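Working notes: methoxycarbonyl to carboxy at the phenyl terminus

The source may hold more compounds than are shown below. What is called first, only, known or untested is meant among the compounds shown, and "the series" means these compounds.

Measured so far:
compound 1, `CC(Oc1ccc(Oc2ccc(F)cc2)cc1)C(=O)Cn1nnc(-c2ccccc2)n1`, gives 24 nM in an assay on microsomes from brain for inhibition of Fatty-acid amide hydrolase 1 (Rattus norvegicus), read by fluorescence and HPLC, with a stated time of 60 min; on this read-out lower numbers stand for stronger inhibition and higher numbers for weaker inhibition.
compound 2, `COC(=O)c1ccc(-c2nnn(CC(=O)C(C)Oc3ccc(Oc4ccc(F)cc4)cc3)n2)cc1`, gives 36 nM in this assay.
compound 3, `COC(=O)c1ccc(-c2nnn(CC(=O)C(C)Oc3ccc(-c4ccccc4)cc3)n2)cc1`, gives 23 nM in this assay.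

Compound 2 sits at the highest of the three numbers, but neither neighbour is separated from it by more than the scatter: a 1.5-fold higher number from compound 1 to compound 2 (0.18 log units; within the scatter) and a 1.6-fold lower number from compound 2 to compound 3 (0.19 log units; within the scatter). On the numbers shown, the three compounds are not told apart.

Compound 4, `CC(Oc1ccc(Oc2ccc(F)cc2)cc1)C(=O)Cn1nnc(-c2ccc(C(=O)O)cc2)n1`, differs from compound 2 by hydrogen in place of methyl on an oxygen next to a carbonyl group. Going by the values given here, no measured step touches this place: the step from compound 1 to compound 2 concerns the methoxycarbonyl group entering, and the step from compound 2 to compound 3 concerns the other end of the molecule. Among the compounds with values here, both were within the scatter, which gives a series so far insensitive to the changes tried, yet offers no direct precedent for removing the methyl from the ester oxygen. The expectation is therefore a 1.7-fold higher number from compound 2 to compound 4 (0.22 log units; within the scatter), with no firm direction and a wide range. Compound 4 is estimated at 60 nM in this assay, expected to fall between 15 nM and 300 nM.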

Compound 4, half-maximal inhibitory concentration: 100 nM
Compound 4: the middle estimate sits 1.7-fold (0.22 log units) below what was measured; measured number inside the range.
By their numbers in this assay, from the lowest: compounds 3, 1 and 2 (each within the scatter of the next); then compound 4.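

In this assay, going by these compounds alone, the step of a 2.8-fold higher number from compound 2 to compound 4 (0.44 log units; beyond the scatter) for hydrogen in place of methyl on an oxygen next to a carbonyl group is the first single change to lie beyond the scatter. The phenyl terminus therefore does not accept every group alike: methoxycarbonyl stays within the scatter of hydrogen, with a 1.5-fold higher number from compound 1 to compound 2 (0.18 log units; within the scatter) on record, whereas carboxy does not, with a 4.2-fold higher number from compound 1 to compound 4 (0.62 log units; beyond the scatter) on record. Nothing available explains why hydrogen and methyl on this oxygen differ.

Going by these compounds, it remains open whether the shift belongs to carboxy alone or would also appear with another group here, such as an ethyl ester, a primary amide or an aminomethyl group. Also open, on these data alone, is whether carboxy gives a similar step when phenyl replaces 4-fluorophenoxy, as in compound 3.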